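Carboxy to hydroxymethyl swap, carried onto a second core

This account rests on a few compounds, and the source may have more. Where it says the series, first, only, none or still open, it means among the compounds named here.

Measured so far:
- compound 1, `C/C=C/C(=O)Nc1ccc(Cn2nc(-c3ccc(Oc4ccccc4)cc3)cc2C(=O)O)cc1`; in a functional assay on Z-138 cells (Homo sapiens) for inhibition, read by luminescence and CellTiter-Glo, with a stated time of 72 h (a lower number here means a stronger inhibitor, a higher number a weaker inhibitor), compound 1 reads > 60000 nM, which is a limit of the assay and not a number.
- compound 2, `C/C=C/C(=O)Nc1ccc(Cn2nc(-c3ccc(Oc4ccccc4)cc3)cc2CO)cc1`; in this assay compound 2 gives 54500 nM.
- compound 3, `C/C=C/C(=O)N1CCCC(n2nc(-c3ccc(Oc4ccccc4)cc3)cc2C(=O)O)C1`; in this assay compound 3 reads > 60000 nM, again a limit of the assay.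

Within the data shown here, the one measured step, an at least 1.1-fold lower number from compound 1 to compound 2 (0.04 log units; that floor lies within the scatter), arises from hydroxymethyl in place of carboxy on an aromatic carbon. Its floor lies within the scatter, so the two values of compound 1 and compound 2 cannot be ordered. The series as a whole sits at the edge of what the assay can resolve, as the limit of > 60000 nM in this assay, at which 2 of the 3 values shown sit, shows.

Compound 3 carries a different core from compound 1; the difference between the two cores is not broken down here.

Compound 4, `C/C=C/C(=O)N1CCCC(n2nc(-c3ccc(Oc4ccccc4)cc3)cc2CO)C1`, is the partner of compound 3 in the same way that compound 2 is the partner of compound 1: hydroxymethyl in place of carboxy on an aromatic carbon. Both place lines read identically, so this is the same change on a second core.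

The expectation for compound 4 rests on the measured step of an at least 1.1-fold lower number from compound 1 to compound 2 (0.04 log units; that floor lies within the scatter), whose floor lies within the scatter, and on the value of compound 3, which is only a limit. The step of a number no higher from compound 3 to compound 4 (the limit leaves the size open) is therefore expected to be small, and it is likely that the assay will again report only a limit. The estimate for compound 4 in this assay is 60000 nM, between 25000 nM and 150000 nM.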

Compound 4, half-maximal inhibitory concentration: 51100 nM
Beside the measured number, compound 4's estimate is 1.2-fold (0.07 log units) above it; the range from low to high includes it.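

On the second core, hydroxymethyl in place of carboxy on an aromatic carbon gives an at least 1.1-fold lower number from compound 3 to compound 4 (0.06 log units; that floor lies within the scatter) in this assay. The same change on the two cores can be set side by side, but the sizes of the two steps cannot be compared: the same change on two cores in this assay, an at least 1.1-fold lower number (0.04 log units; that floor lies within the scatter) from compound 1 to compound 2 and an at least 1.1-fold lower number (0.06 log units; that floor lies within the scatter) from compound 3 to compound 4; the limit leaves it open whether they differ

Compound 2 and compound 4 each give a number where their carboxy partners give only a limit, but this does not show that the change has a real effect on either core, or the same effect on both, and the whole set stays at the edge of what the assay resolves: the limit of > 60000 nM in this assay, at which 2 of the 4 values shown sit.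

Left open is whether any other group on that same aromatic carbon, such as an amine, a methyl ester or a primary carboxamide, would give a value clearly apart from those of the carboxy and hydroxymethyl compounds on either core. Also open, as far as these compounds go, is whether the core of compound 1 and the core of compound 3 would separate once a group on that carbon gives values well clear of the limit.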